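The source may report more compounds than this note shows. Statements on the series, on what has been measured and on what is new or still open speak of the compounds shown alone.

Working notes on the series. The shared core, a piperazine carrying a benzodioxane or benzodioxepine on one nitrogen and an aryl-bearing chain on the other, is tested in an assay for activation of Adrenergic receptor alpha-1 (Rattus norvegicus); a higher number here means that more compound is needed for the effect, a lower number that less compound is needed. Compound 1 `C1=C(CCN2CCN(c3cccc4c3OCCO4)CC2)c2ccccc2CCC1` reaches only the assay limit of > 2.5 mg/kg, so no number stands for it. Within the data shown here, compound 2 `c1ccc2c(c1)CC2CCN1CCN(c2cccc3c2OCCCO3)CC1` gives 6.96 mg/kg and compound 3 `COc1cc2c(cc1OC)C(CCN1CCN(c3cccc4c3OCCO4)CC1)CC2` gives 10 mg/kg; these two sit within the usual scatter of each other, so no order between them can be read, and this is the one number-bearing pair in this assay (the limit of > 2.5 mg/kg in this assay, at which 1 of the 3 values shown sits).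

Compound 4 `c1ccc2c(c1)CC2CN1CCN(c2cccc3c2OCCCO3)CC1` is the next entry. It differs from compound 2 as follows: a group of 8 heavy atoms (8 carbon; one four-membered non-aromatic ring of carbon only, one six-membered aromatic ring of carbon only) in place of a group of 9 heavy atoms (9 carbon; one four-membered non-aromatic ring of carbon only, one six-membered aromatic ring of carbon only), on a saturated chain carbon bound to an amine nitrogen in a ring. Among the measured compounds shown here, no measured pair shows a shortening of this kind, so the size and direction of the step cannot be taken from the data. With compound 2 at 6.96 mg/kg and the shorter chain untested, the expectation for compound 4 is placed near the measured range, leaning toward a somewhat higher number, giving an expected value of 12 mg/kg in this assay, with a range from 4 mg/kg to 35 mg/kg. The expected step of a 1.7-fold higher number from compound 2 to compound 4 (0.24 log units; within the scatter) is accordingly a moderate one toward more compound being needed, and a limit result is also possible.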

Compound 4, dose for half-maximal effect: < 2.5 mg/kg
Compound 4: no number, only a limit; the forecaster's own chance of this, stated with the estimate: 20%; at least 4.8-fold (0.68 log units) between middle value and limit.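

Among these compounds, at the position on a saturated chain carbon bound to an amine nitrogen in a ring, the group of 8 heavy atoms in place of the group of 9 heavy atoms gives the first readable step in this assay, and it lies beyond the scatter: an at least 2.7-fold lower number from compound 2 to compound 4 (0.44 log units; beyond the scatter). On these data alone, the step ends on a limit and not on a number, so its direction can be read, while its full size stays open: the limit of < 2.5 mg/kg in this assay, at which 1 of the 4 values shown sits. The two groups share the same rings and have no hydrogen-bond donors, no hydrogen-bond acceptors and no net charge, so within this one pair they differ only in their carbon count, and the number in this assay responds to that difference.

A single pair on a single core leaves open whether the same change would give a step of this direction on the cores of compound 1 or compound 3. The compounds shown also leave open how the number would respond to a longer chain, or to a hydroxyl group or an amine on the chain at this position.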